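From compound 3 to compound 4: heptyl for 4-(dimethylamino)phenyl

The source may hold more compounds than are shown below. What is called first, only, known or untested is meant among the compounds shown, and "the series" means these compounds.

In a functional assay on HeLa cells (Homo sapiens) for inhibition, read by MTT assay, with a stated time of 48 h (on this read-out lower numbers stand for stronger inhibition and higher numbers for weaker inhibition), compound 1 `c1ccc(C(c2c[nH]c3ccccc23)c2c[nH]c3ccccc23)cc1` gives 21800 nM and compound 2 `Oc1ccc(C(c2c[nH]c3ccc(Br)cc23)c2c[nH]c3ccc(Br)cc23)cc1` gives 4000 nM. Compound 3 `CN(C)c1ccc(C(c2c[nH]c3ccc(Br)cc23)c2c[nH]c3ccc(Br)cc23)cc1` gives 12800 nM, within the scatter of compound 1 and a number clearly higher than that of compound 2.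

Compound 4 `CCCCCCCC(c1c[nH]c2ccc(Br)cc12)c1c[nH]c2ccc(Br)cc12` carries this change: heptyl in place of 4-(dimethylamino)phenyl on a saturated chain carbon bound to two aromatic carbons.

Going by the values given here, the only measured step at this group is modest: a 3.2-fold higher number from compound 2 to compound 3 (0.51 log units; beyond the scatter). Among the compounds with values here, it leaves the ring in place, so it bears only loosely, and no measured compound lacks that ring. No clear direction follows, and the expected step stays within the scatter: a 1.3-fold lower number from compound 3 to compound 4 (0.11 log units; within the scatter). The estimated value for compound 4 is 10000 nM, with an expected range of 3000 nM to 30000 nM.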

Compound 4, half-maximal inhibitory concentration: 1300 nM
For compound 4 the middle estimate is 7.7-fold (0.89 log units) above the measured one; the measured number lies below the stated range.
By their numbers in this assay, from the lowest: compound 4; then compound 2; then compounds 3 and 1 (each within the scatter of the next).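

In this assay, an aromatic ring is not needed on the saturated chain carbon bound to two aromatic carbons: replacing 4-(dimethylamino)phenyl with heptyl gives a 9.8-fold lower number from compound 3 to compound 4 (0.99 log units; beyond the scatter). The open chain also improves on the 4-hydroxyphenyl group, with a 3.1-fold lower number from compound 2 to compound 4 (0.49 log units; beyond the scatter), so the better of the two ring substituents does not match it. Nothing available on these compounds accounts for the chain's advantage.

Still open, going by these compounds, is whether a shorter chain such as butyl or a longer chain such as decyl lowers the number further. A cyclohexyl group or a chain ending in an amine or a carboxylic acid would test how much the result depends on an all-carbon, ring-free substituent.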